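Carboxymethyl to 1-carboxyethyl in compound 2

This account rests on a few compounds, and the source may have more. Where it says the series, first, only, none or still open, it means among the compounds named here.

- Compound 1 `O=C(O)Cn1nc(Cc2cn3cc(OCC4CC4)c(Cl)cc3n2)c2ccccc2c1=O`: > 1000 ug/mL, a limit of the assay and not a number
- Compound 2 `O=C(O)Cc1nn(Cc2cn3cc(OCC4CC4)c(Cl)cc3n2)c2ccccc2c1=O`: 919 ug/mL
- Compound 3 `CC(C(=O)O)c1nn(Cc2cn3cc(OCC4CC4)c(C(F)(F)F)cc3n2)c2ccccc2c1=O`: 221 ug/mL

These values come from a physicochemical assay for solubility, measured as thermodynamic solubility, at pH 7.4; a higher number here means a more soluble compound, a lower number a less soluble compound. Of the two true numbers, compound 2 has the higher, 919 ug/mL, and compound 3 the lower, 221 ug/mL, a gap beyond the usual scatter.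

Compound 4 `C[C@H](C(=O)O)c1nn(Cc2cn3cc(OCC4CC4)c(Cl)cc3n2)c2ccccc2c1=O` has not yet been measured. It differs from compound 2 by methyl in place of hydrogen on a saturated chain carbon bound to an aromatic carbon and a carbonyl carbon. The same difference reads carboxymethyl to 1-carboxyethyl.

Within the data shown here, no measured pair shows this change alone. Compound 3 also carries a 1-carboxyethyl group and gives 221 ug/mL, but it differs from compound 4 elsewhere too, so it is only a loose guide to a lower number. The expected change is a 1.8-fold lower number from compound 2 to compound 4 (0.26 log units; within the scatter), a small downward step within the usual scatter. Compound 4 is estimated at 500 ug/mL, with an expected range from 200 ug/mL to 1000 ug/mL.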

Compound 4, solubility: 892 ug/mL
Compound 4: the middle estimate sits 1.8-fold (0.25 log units) below what was measured; the measured number falls inside the stated range.
By their numbers in this assay, from the lowest: compound 3; then compounds 4 and 2 (each within the scatter of the next). At a limit, above all of these: compound 1.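

In this assay, this is the one comparison shown in which a single change stands alone, and the two compounds cannot be told apart: a 1.0-fold lower number from compound 2 to compound 4 (0.01 log units; within the scatter). Among these compounds, compound 3 also carries a 1-carboxyethyl group but differs elsewhere too, so only this pair isolates methyl in place of hydrogen on this saturated chain carbon, and here the added methyl leaves no readable mark. Compound 1 gives a limit and not a number, so it has no part in this reading: the limit of > 1000 ug/mL in this assay, at which 1 of the 4 values shown sits.

One small methyl at one carbon is all this pair covers, so a longer chain such as ethyl, or a second methyl on the same carbon, remains an open question. Going by these compounds, it is also open whether an amine in place of the carboxylic acid would give a number in the same range.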